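Removing one chloro from the core of compound 3

This account rests on a few compounds, and the source may have more. Where it says the series, first, only, none or still open, it means among the compounds named here.

Compound 1 `ClCc1ccc(Cn2cnc3c(Cl)ncnc32)cc1`: 2450 nM
Compound 2 `Nc1nc(Cl)c2ncn(Cc3ccccc3CCl)c2n1`: > 100000 nM
Compound 3 `ClCc1ccccc1Cn1cnc2nc(Cl)nc(Cl)c21`: 4070 nM

In a functional assay on HCT-116 cells (Homo sapiens) for cytotoxicity, read by sulforhodamine B assay, with a stated time of 48 h (a higher number here means a weaker inhibitor of growth, a lower number a stronger inhibitor of growth), compound 3 gives 4070 nM, the highest of the two numbers shown. Its nearest neighbour is compound 1, which gives 2450 nM, a gap within the usual scatter. For compound 2 the assay reports only a limit, > 100000 nM, and no number (the limit of > 100000 nM in this assay, at which 1 of the 3 values shown sits).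

Compound 4 `ClCc1ccccc1Cn1cnc2ncnc(Cl)c21` differs from compound 3 in one place: hydrogen in place of chloro on an aromatic carbon. For the measured compounds named here, no step between measured compounds matches this change, so compound 1, which carries the same single chloro on its core, offers the only guide, and its number sits close to that of compound 3. Compound 4 is therefore expected to show no step beyond the scatter, a 1.4-fold lower number from compound 3 to compound 4 (0.13 log units; within the scatter), and its value in this assay is estimated at 3000 nM, between 1000 nM and 9000 nM.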

Compound 4, concentration for total growth inhibition: 4070 nM
For compound 4 the middle estimate is 1.4-fold (0.13 log units) below the measured one; the measured number falls inside the stated range.
By their numbers in this assay, from the lowest: compounds 1, 3 and 4 (each within the scatter of the next). At a limit, above all of these: compound 2.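

Hydrogen in place of chloro on this aromatic carbon, between two ring nitrogen atoms, brings no change at the digits printed from compound 3 to compound 4 (within the scatter) in this assay and is the first direct reading at this position. The chloro here can therefore be lost from compound 3 with no change beyond the scatter. Nothing shown accounts for this flat step. As far as these compounds go, whether an amine, a methoxy group or a longer chain on this carbon would leave the number equally unmoved stays open. So does the effect of replacing the remaining chloro on the core of compound 4.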